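Replacing phenoxy with fluoro on a shared core

The compounds below may be only part of what the source reports. "The series", "measured", "known", "first", "only" and "open" are said of these compounds alone.

Compound 1 `CC(C)[C@H](NC(=O)COc1cccc2ccccc12)C(=O)N[C@@H](CC(=O)O)C(=O)COc1cccc(C(F)(F)F)c1`: 16600 nM
Compound 2 `CC(C)[C@H](NC(=O)COc1cccc2ccccc12)C(=O)N[C@@H](CC(=O)O)C(=O)COc1ccc(Oc2ccccc2)cc1`: 19000 nM

In a functional assay with Homo sapiens as the target (a lower number here means a stronger inhibitor, a higher number a weaker inhibitor), compound 2 gives 19000 nM, which lies within the usual scatter of compound 1 at 16600 nM. Compound 3 `CC(C)[C@H](NC(=O)COc1cccc2ccccc12)C(=O)N[C@@H](CC(=O)O)C(=O)COc1ccc(F)cc1` has fluoro in place of phenoxy on an aromatic carbon, para to a large group: fluoro in place of phenoxy on an aromatic carbon. Going by the values given here, no measured pair shows this exact change. The two compounds carry different groups, yet their values differ by no more than the scatter. For this reason, no change beyond the scatter is expected in this assay, and the estimated step is a 1.4-fold lower number from compound 2 to compound 3 (0.13 log units; within the scatter). For compound 3, the estimated value is 14000 nM, with an expected range of 5000 nM to 40000 nM.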

Compound 3, half-maximal inhibitory concentration: 14300 nM
Compound 3: the middle estimate sits 1.0-fold (0.01 log units) below what was measured; measured number inside the range.
By their numbers in this assay, from the lowest: compounds 3, 1 and 2 (each within the scatter of the next).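

In this assay, fluoro in place of phenoxy on this aromatic carbon, para to a large group, gives a 1.3-fold lower number from compound 2 to compound 3 (0.12 log units; within the scatter) and so shows that this exact change, which removes a whole aromatic ring, leaves the number within the scatter. The 4-fluorophenyl in place of 3-(trifluoromethyl)phenyl gives a 1.2-fold lower number from compound 1 to compound 3 (0.06 log units; within the scatter) and extends this to a second change of the group on that oxygen. Nothing available here accounts for this lack of difference.

Going by these compounds, whether an amine or a carboxylic acid on that aromatic carbon would shift the number beyond the scatter stays open. So does the effect of changes elsewhere on the shared core.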